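This account rests on a few compounds, and the source may have more. Where it says the series, first, only, none or still open, it means among the compounds named here.

Measured in a functional assay on the whole organism for inhibition, with Rattus norvegicus as the target, read by paw edema; a lower number here means that less compound is needed, a higher number that more compound is needed for the effect:
compound 1 `O=C(O)c1ccc(-c2cscn2)cc1O` — 70 mg/kg
compound 2 `O=C(O)c1cc(-c2cscn2)ccc1O` — 95 mg/kg
compound 3 `O=C(O)c1cc(-c2cocn2)ccc1O` — 110 mg/kg

Compound 3 gives the highest of the three numbers in this assay, but its distances to compound 2 and to compound 1 are both within the scatter, so no order among the three is claimed. Compound 4 `O=C(O)c1cc(-c2ncc[nH]2)ccc1O` differs from compound 3 as follows: 1H-imidazol-2-yl in place of 1,3-oxazol-4-yl on an aromatic carbon. Within the data shown here, only one measured step bears on an exchange of the five-membered ring on the aromatic carbon: a 1.2-fold higher number from compound 2 to compound 3 (0.06 log units; within the scatter). Among the measured compounds shown here, no measured compound carries the 1H-imidazol-2-yl group, so the new ring itself is untested. Because a 1.2-fold higher number from compound 2 to compound 3 (0.06 log units; within the scatter) stayed within the scatter, no step beyond the scatter is expected for compound 4 either: no change at the digits printed from compound 3 to compound 4 (within the scatter). Compound 4 is therefore expected to give about 110 mg/kg in this assay, within 55 mg/kg to 220 mg/kg.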

Compound 4, dose for half-maximal effect: 200 mg/kg
Beside the measured number, compound 4's estimate is 1.8-fold (0.26 log units) below it, within the range that was stated.
By their numbers in this assay, from the lowest: compounds 1, 2, 3 and 4 (each within the scatter of the next, the first and the last beyond it).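

In this assay, exchanging the ring on the aromatic carbon para to the hydroxy group is no longer always silent: 1H-imidazol-2-yl gives a 1.8-fold higher number from compound 3 to compound 4 (0.26 log units; within the scatter) against 1,3-oxazol-4-yl and a 2.1-fold higher number from compound 2 to compound 4 (0.32 log units; beyond the scatter) against 1,3-thiazol-4-yl. Only the latter exchange passes the scatter, and only modestly. Unlike 1,3-oxazol-4-yl, the entering ring has a hydrogen-bond donor, but nothing available connects that difference to the step. Open, on these data alone, is whether a 1-methyl-1H-imidazol-2-yl group or a phenyl ring at this place would follow the same step. Also open, as far as these compounds go, is whether 1H-imidazol-2-yl would give a similar step at the ring position of compound 1.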